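This account rests on a few compounds, and the source may have more. Where it says the series, first, only, none or still open, it means among the compounds named here.

Measured compounds:
- compound 1 `CC/C=C/C(=O)Nc1cc2c(N3CCCc4ccccc43)ncnc2cc1O[C@@H]1CCOC1` — in a functional assay on PC-3 cells (Homo sapiens) for antiproliferative activity, read by MTT assay, with a stated time of 72 h (a higher number here means a weaker inhibitor, a lower number a stronger inhibitor), compound 1 gives 14300 nM
- compound 2 `O=C(/C=C/CN1CCCCC1)Nc1cc2c(N3CCc4ccccc43)ncnc2cc1O[C@@H]1CCOC1` — in this assay compound 2 gives 4510 nM
- compound 3 `COc1cc2ncnc(N3CCCc4ccccc43)c2cc1NC(=O)/C=C/CN1CCCCC1` — in this assay compound 3 gives 5780 nM

Compound 3 stands second highest of the three numbers. Its nearest neighbour is compound 2, whose number is lower by an amount within the usual scatter, so the two cannot be ordered. Compound 1 lies furthest from it, with a higher number, a gap beyond the scatter.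

Compound 4 `O=C(/C=C/CN1CCCCC1)Nc1cc2c(N3CCCc4ccccc43)ncnc2cc1O[C@@H]1CCOC1` is not yet measured. It differs from compound 3 in one place: oxolan-3-yl in place of methyl on an oxygen on an aromatic ring. Among the compounds with values here, no pair of measured compounds differs only in this place, so no directly comparable step exists. Compound 2 also carries the (oxolan-3-yl)oxy group together with the same amide chain, and its number lies within the scatter of compound 3. On that basis the change is expected to give a step of a 1.2-fold lower number from compound 3 to compound 4 (0.08 log units; within the scatter) of no more than the scatter, in no fixed direction. Compound 4 is thus estimated at 4800 nM, in a range from 1600 nM to 14000 nM.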

Compound 4, half-maximal inhibitory concentration: 3630 nM
Beside the measured number, compound 4's estimate is 1.3-fold (0.12 log units) above it, and the stated range covers the measured number.
By their numbers in this assay, from the lowest: compounds 4, 2 and 3 (each within the scatter of the next); then compound 1.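

In this assay the change from methoxy to (oxolan-3-yl)oxy gives a 1.6-fold lower number from compound 3 to compound 4 (0.20 log units; within the scatter), so this place on the shared core accepts the larger ring-bearing group with no resolved effect on the number. Within the data shown here, the exchange of 2,3-dihydro-1H-indol-1-yl for 1,2,3,4-tetrahydroquinolin-1-yl gives a 1.2-fold lower number from compound 2 to compound 4 (0.09 log units; within the scatter), also unresolved, whereas piperidin-1-yl in place of methyl on the saturated chain carbon gives a 3.9-fold lower number from compound 1 to compound 4 (0.60 log units; beyond the scatter), the only one of these steps beyond the scatter. Nothing available explains any of these steps.

Open, as far as these compounds go, is whether a hydroxy group or a longer alkoxy chain on that oxygen, or the opposite configuration at the oxolane stereocentre, would fall within the same range. Also open, from the compounds shown here alone, is whether a morpholine or a dimethylamino group in place of piperidin-1-yl would hold the gain seen on the chain.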